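From 4-methyl to 4,4-dimethyl-2-oxopyrrolidin-1-yl

A few compounds are considered here, and "the series" means these few. Any claim that something is new, unique, unknown or untested is made for them only; others in the source may bear on it.

Compound 1 `Fc1ccc2c(c1CNc1ncc(Oc3ccccc3)c3nncn13)CCO2`: 18 mL.min-1.g-1
Compound 2 `C[C@@H]1CC(=O)N(c2cnc(NCc3c(F)ccc4c3CCO4)n3cnnc23)C1`: < 3 mL.min-1.g-1

Both compounds were measured in an ADME assay on microsomes from liver (Homo sapiens) for metabolic stability, read by LC-MS, using NADPH, with stated times of 5 min and 30 min, tested at 1 uM; on this read-out higher numbers stand for fast clearance and lower numbers for slow clearance. Compound 1 gives 18 mL.min-1.g-1. Compound 2 gives < 3 mL.min-1.g-1, which is a limit of the assay and not a number.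

For the measured compounds named here, the one measured step is an at least 6.0-fold lower number from compound 1 to compound 2 (0.77 log units; beyond the scatter). It puts 4-methyl-2-oxopyrrolidin-1-yl in place of phenoxy on an aromatic carbon, and it lies beyond the scatter.

Going by the values given here, compound 3 `CC1(C)CC(=O)N(c2cnc(NCc3c(F)ccc4c3CCO4)n3cnnc23)C1` keeps the shared core and alters only that group, with 4,4-dimethyl-2-oxopyrrolidin-1-yl in place of 4-methyl-2-oxopyrrolidin-1-yl on an aromatic carbon. This is a far smaller swap than the one in an at least 6.0-fold lower number from compound 1 to compound 2 (0.77 log units; beyond the scatter), which replaced phenoxy with a different kind of group. Among the compounds with values here, no measured step tests the new change directly, so the expectation in this assay is for no step beyond the scatter, with compound 3 staying near the limit of compound 2.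

The estimated step is an at least 1.1-fold higher number from compound 2 to compound 3 (0.06 log units; that floor lies within the scatter). For compound 3 the expected value is 3.5 mL.min-1.g-1, with an expected range of 2 mL.min-1.g-1 to 8 mL.min-1.g-1.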

Compound 3, intrinsic clearance in microsomes: 16 mL.min-1.g-1
For compound 3 the middle estimate is 4.6-fold (0.66 log units) below the measured one, and the stated range ends below it.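

In this assay, this position on the aromatic carbon proves sensitive to a very small change: 4,4-dimethyl-2-oxopyrrolidin-1-yl in place of 4-methyl-2-oxopyrrolidin-1-yl gives an at least 5.3-fold higher number from compound 2 to compound 3 (0.72 log units; beyond the scatter), so the low number of compound 2 does not come with the 2-oxopyrrolidin-1-yl ring as such. The swap from phenoxy to the same dimethyl group gives a 1.1-fold lower number from compound 1 to compound 3 (0.05 log units; within the scatter), which means that this lactam alone does not separate the new compound from the phenoxy compound on this read-out. Compound 2 gives a limit of the assay and not a number, so the step from it has only a floor and its true size may be larger: the limit of < 3 mL.min-1.g-1 in this assay, at which 1 of the 3 values shown sits.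

The entering group also has no defined stereocentre, so the added methyl and the loss of the stereocentre cannot be told apart here. Open too, on these data alone, is where the mirror-image form of compound 2 would fall, and where a 2-oxopyrrolidin-1-yl ring with no methyl at all, or one carrying a 4-ethyl group or an amine, would fall.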